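This account rests on a few compounds, and the source may have more. Where it says the series, first, only, none or still open, it means among the compounds named here.

Measured in an ADME assay on Vero cells (Chlorocebus sabaeus) for cytotoxicity, read by neutral red uptake, tested at 1575 ug/mL; a lower number here means a stronger effect, a higher number a weaker effect of the compound at the concentration tested:
compound 1 `COc1ccc(C2SCC(=O)N2CCN2CCCCC2)cc1` gives 11%
compound 2 `O=C1CSC(c2cccc(F)c2)N1CCN1CCCCC1` gives 17%
compound 3 `O=C1CSC(c2ccccc2Cl)N1CCN1CCCCC1` gives 16%

All three numbers in this assay sit close together. Compound 3 is second highest of the three; its nearest neighbour is compound 2, and the gap between the two values is within the scatter, as is the gap to compound 1, the furthest of the three. Nothing in this set separates one compound from another beyond the usual spread of repeated measurements.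

Compound 4 `O=C1CSC(c2ccc(Cl)cc2)N1CCN1CCCCC1` is the next member. It differs from compound 3 in one place: 4-chlorophenyl in place of 2-chlorophenyl on a saturated ring carbon. Among the compounds with values here, the only measured step that bears on it is the exchange of one halogenated phenyl for another on the same saturated ring carbon, a number 1 percentage points lower from compound 2 to compound 3 (within the scatter), which stayed within the scatter. Within the data shown here, there is no measured step that moves the chlorine around the ring, so the expectation rests on that single exchange and on the flatness of the set as a whole.

On this basis compound 4 is expected to show no step beyond the scatter, no change at the digits printed from compound 3 to compound 4 (within the scatter). Compound 4 is therefore estimated at 16%, with a range from 7% to 27%.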

Compound 4, a percentage reported as activity, at one concentration (the size of the read-out at that concentration, not a potency): 13%
The estimate for compound 4 lay 3 percentage points above the measured number; the range from low to high includes it.
By their numbers in this assay, from the lowest: compounds 1, 4, 3 and 2 (each within the scatter of the next).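

In this assay, within the data shown here, 4-chlorophenyl in place of 2-chlorophenyl on the saturated ring carbon gives a number 3 percentage points lower from compound 3 to compound 4 (within the scatter) and is the first direct read on where the chlorine stands on this phenyl: across these two placements, the read-out does not separate beyond the scatter. The comparisons with the other aryl groups agree, since 4-chlorophenyl in place of 3-fluorophenyl gives a number 4 percentage points lower from compound 2 to compound 4 (within the scatter) and chloro in place of methoxy on an aromatic carbon gives a number 2 percentage points higher from compound 1 to compound 4 (within the scatter) in the same read-out, so all four compounds remain one flat group at this position. No available evidence bears on why these values stay so close together.

The compounds shown carry only a halogen or a methoxy group on the phenyl, so it remains open whether a carboxylic acid or an amine there would give a step beyond the scatter. Among these compounds, also open is whether a longer chain in place of the group of 8 heavy atoms on the neighbouring ring atom would separate from this set, and the single tested concentration gives no potency for any member.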